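From Phenyl to tert-Butyl in a Small Inhibitor Series

This account rests on a few compounds, and the source may have more. Where it says the series, first, only, none or still open, it means among the compounds named here.

Measured so far in a functional assay on a cell-free system (plasma, Homo sapiens), with a stated time of 3 min; a higher number here means a weaker inhibitor, a lower number a stronger inhibitor
- compound 1 `O=C(NCc1cc(Cl)ccc1-n1cnnn1)[C@@H]1CCNN1C(=O)[C@H](O)c1ccccc1` gives 930 nM
- compound 2 `O=C(NCc1cc(Cl)ccc1-n1cnnn1)[C@@H]1[C@H]2C[C@H]2CN1C(=O)[C@H](O)C1CCCCC1` gives 850 nM
- compound 3 `CC(C)(C)[C@@H](O)C(=O)N1[C@H](C(=O)NCc2cc(Cl)ccc2-n2cnnn2)C[C@@H]2C[C@@H]21` gives 1500 nM

These three numbers all lie within the usual scatter of repeated measurements, so they cannot be ranked. Compound 1 (930 nM) therefore stands level with the other two and offers a fair reference point.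

Compound 4 `CC(C)(C)[C@@H](O)C(=O)N1NCC[C@H]1C(=O)NCc1cc(Cl)ccc1-n1cnnn1` has not yet been measured. It has tert-butyl in place of phenyl on a saturated chain carbon bound to a carbonyl carbon and an oxygen on a saturated carbon. Among the measured compounds shown here, no measured pair shows this swap on its own, so the evidence is thin. For the measured compounds named here, compound 3 (1500 nM) also carries a tert-butyl group, and its value offers the only guide.

In this assay the expected change is small and points towards a higher number, meaning a slightly weaker inhibitor, without clearly leaving the scatter: a 1.5-fold higher number from compound 1 to compound 4 (0.18 log units; within the scatter) is the estimated step. The estimate for compound 4 is 1400 nM, with an expected range from 500 nM to 3500 nM.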

Compound 4, half-maximal inhibitory concentration: 1700 nM
The estimate for compound 4 lay 1.2-fold (0.08 log units) below the measured number, within the range that was stated.
By their numbers in this assay, from the lowest: compounds 2, 1, 3 and 4 (each within the scatter of the next).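

In this assay the swap of phenyl for tert-butyl on a saturated chain carbon bound to a carbonyl carbon and an oxygen on a saturated carbon can now be read on its own, with the rest of the core of compound 1 unchanged (a 1.8-fold higher number from compound 1 to compound 4 (0.26 log units; within the scatter)). At this place, then, the six-membered aromatic ring can give way to a group with no ring, and the step stays within the scatter of repeated measurements. Nothing measured here gives a reason for the size of this step.

From the compounds shown here alone, whether a methyl group, an amine or a carboxylic acid in the same place would give a step beyond the scatter stays open. Cyclohexyl appears only in compound 2, on a different core, so the effect of that group on the core of compound 1 is also open.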